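Adding a second hydroxy group to compound 1

This account rests on a few compounds, and the source may have more. Where it says the series, first, only, none or still open, it means among the compounds named here.

Compound 1 `Oc1ccccc1CNc1ncnc2c1ncn2C1CCCCO1`: > 100000 nM
Compound 2 `COc1ccc(CNc2ncnc3c2ncn3C2CCCCO2)c(OC)c1`: > 25000 nM
Compound 3 `COc1cc(CNc2ncnc3c2ncn3C2CCCCO2)cc(OC)c1`: > 100000 nM

All three compounds were tested in an ADME assay on BJ cells (Homo sapiens) for cytotoxicity, read by MTT assay, with a stated time of 72 h (on this read-out lower numbers stand for stronger inhibition and higher numbers for weaker inhibition), and none gave a number. Compound 1 gives > 100000 nM, which is a limit. Compound 2 gives > 25000 nM, also a limit. Compound 3 gives > 100000 nM, again a limit. Compound 1 thus stands at the limit of > 100000 nM in this assay, at which 2 of the 3 values shown sit.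

Compound 4 `Oc1cccc(CNc2ncnc3c2ncn3C2CCCCO2)c1O` awaits measurement in this assay. It takes 2-hydroxyphenyl to 2,3-dihydroxyphenyl: hydroxy in place of hydrogen on an aromatic carbon. Among the measured compounds shown here, no measured pair shows this change, so the expectation rests on the limit of compound 1 alone. The expected step of an at least 1.2-fold lower number from compound 1 to compound 4 (0.09 log units; that floor lies within the scatter) is small, towards stronger inhibition if it shows at all. For compound 4 the estimate is 80000 nM, with an expected range of 25000 nM to 200000 nM.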

Compound 4, half-maximal inhibitory concentration: 63300 nM
Beside the measured number, compound 4's estimate is 1.3-fold (0.10 log units) above it; measured number inside the range.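

Compound 4 is the first of these compounds to give a number rather than a limit in this assay. Hydroxy in place of hydrogen on this aromatic carbon, ortho to a hydroxy group, brings an at least 1.5-fold lower number from compound 1 to compound 4 (0.19 log units; that floor lies within the scatter), so the change is not shown to exceed the usual scatter. The step has only a floor, since compound 1 rests on a limit: the limit of > 100000 nM in this assay, at which 2 of the 4 values shown sit.

The compounds shown leave open how far the number would move with an amine or a carboxylic acid at this position in place of the hydroxy group.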